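A few compounds are considered here, and "the series" means these few. Any claim that something is new, unique, unknown or untested is made for them only; others in the source may bear on it.

In a toxicity assay on HEK-293T cells (Homo sapiens) for cytotoxicity, read by MTT assay, with a stated time of 72 h (on this read-out higher numbers stand for weaker inhibition and lower numbers for stronger inhibition), compound 1 `O=C1c2c[n+]([O-])c3ccccc3c2C(=O)c2c1c1ccccc1n2CCCCn1ccnc1` gives 280 nM and compound 2 `O=C1c2c[n+]([O-])c3ccccc3c2C(=O)c2c1c1ccccc1n2Cc1cn(C[C@H](O)CO)nn1` gives 8880 nM. Compound 2 therefore holds the higher of the two numbers, meaning weaker inhibition of cell growth. Compound 3 `O=C1c2c[n+]([O-])c3ccccc3c2C(=O)c2c1c1ccccc1n2Cc1cn([C@@H]2O[C@H](CO)[C@@H](O)[C@H](O)[C@H]2O)nn1` has not yet been measured. It differs from compound 2 in one place, with 3,4,5-trihydroxy-6-(hydroxymethyl)oxan-2-yl in place of 2,3-dihydroxypropyl on an aromatic nitrogen.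

Going by the values given here, only one measured step can serve as a guide. This is a 32-fold higher number from compound 1 to compound 2 (1.50 log units; beyond the scatter), a large rise that came with 1-(2,3-dihydroxypropyl)-1H-1,2,3-triazol-4-yl in place of 3-(1H-imidazol-1-yl)propyl. That step exchanged a whole side chain, whereas the new change leaves the five-membered aromatic ring in place and alters only the group on its nitrogen. Among the compounds with values here, no measured pair shows this kind of exchange, and a step of similar size is not expected. Within the data shown here, a small upward change is expected, continuing the direction of the one step seen, although the evidence for that direction is thin. The expected step is a 1.6-fold higher number from compound 2 to compound 3 (0.20 log units; within the scatter). For compound 3, the estimated value is 14000 nM, with an expected range from 5000 nM to 40000 nM.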

Compound 3, half-maximal inhibitory concentration: 940 nM
The estimate for compound 3 lay 15-fold (1.17 log units) above the measured number, and the stated range ends above it.
By their numbers in this assay, from the lowest: compound 1; then compound 3; then compound 2.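

Within this assay the exchange of 2,3-dihydroxypropyl for 3,4,5-trihydroxy-6-(hydroxymethyl)oxan-2-yl brings a 9.4-fold lower number from compound 2 to compound 3 (0.98 log units; beyond the scatter) and so stronger inhibition of cell growth. The earlier step replaced a whole side chain, so it could not show what the group on this nitrogen contributes alone; here the five-membered aromatic ring and the shared core stay the same, and the number still moves beyond the usual scatter. In this one pair, the entering group has more heavy atoms, a six-membered non-aromatic ring, and more hydrogen-bond donors and acceptors, yet the number falls rather than rises, the opposite direction to the earlier step.

The data shown give no explanation for this fall. Also open, from the compounds shown here alone, is which feature of the entering group goes with the lower number, and whether an amine, a carboxylic acid or a longer chain on the same nitrogen would lower the number further or raise it again.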